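The source may hold more compounds than are shown below. What is called first, only, known or untested is meant among the compounds shown, and "the series" means these compounds.

Within the data shown here, in an ADME assay on HEK293 cells (Homo sapiens) for cytotoxicity, read by resazurin assay, with a stated time of 48 h (on this read-out lower numbers stand for higher toxicity in this test and higher numbers for lower toxicity in this test), compound 1 `Cc1ccc(S(=O)(=O)Nc2ccc3oc(-c4ccccc4)nc3c2)cc1` gives 75000 nM, the only actual number among the measured compounds. Compound 2 `O=S(=O)(Nc1ccc(-c2nc3ccccc3o2)cc1)c1ccc(Cl)s1` returns only a limit of > 100000 nM. Compound 3 `CS(=O)(=O)Nc1ccc(-c2nc3ccccc3o2)cc1` likewise returns only a limit of > 100000 nM. Neither of these two shares the core of compound 1.

Compound 4 `O=S(=O)(Nc1ccc2oc(-c3ccccc3)nc2c1)c1cccc(Cl)c1` keeps the core of compound 1 and changes a single group: 3-chlorophenyl in place of 4-methylphenyl on a sulfonyl sulfur. In words, 3-chlorophenyl stands in place of 4-methylphenyl on a sulfonyl sulfur, and the counted heavy atoms stay level.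

Among the measured compounds shown here, the only measured step at such a position is a step that the two limits leave unreadable from compound 2 to compound 3, where methyl replaces 5-chlorothiophen-2-yl. It therefore offers no size to carry over. The remaining evidence is the limit of > 100000 nM in this assay, at which 2 of the 3 values shown sit, which shows how close these compounds lie to the top of the measurable range. For the measured compounds named here, no measured step supports a shift in either direction, so the expectation stays anchored on compound 1 at 75000 nM. The expected size of a 1.1-fold lower number from compound 1 to compound 4 (0.03 log units; within the scatter) is no larger than the usual scatter, with no direction favoured. For compound 4 the estimated value is 70000 nM, with an expected range from 30000 nM to 100000 nM.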

Compound 4, half-maximal cytotoxic concentration: 70000 nM
The estimate for compound 4 equals the measured number at the digits printed, and the stated range covers the measured number.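

In this assay, the step at the sulfonyl sulfur on the core of compound 1 can be read, giving a 1.1-fold lower number from compound 1 to compound 4 (0.03 log units; within the scatter), whereas the earlier step between compound 2 and compound 3 cannot be read. The group that leaves, 4-methylphenyl, and the group that enters, 3-chlorophenyl, have the same count of heavy atoms and each is one six-membered aromatic ring of carbon only, so this pair shows that exchanging these two groups at this position leaves the read-out within the scatter. It also adds a second actual number to a set in which the other values give no size, and the read-out offers little room at its upper end: the limit of > 100000 nM in this assay, at which 2 of the 4 values shown sit.

As far as these compounds go, whether an amine, a carboxylic acid or a longer alkyl chain on the sulfonyl sulfur would shift the number on this core remains open. A single pair also cannot tell whether the same exchange would behave alike on the core shared by compound 2 and compound 3.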